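This account rests on a few compounds, and the source may have more. Where it says the series, first, only, none or still open, it means among the compounds named here.

In a functional assay on MV4-11 cells (Homo sapiens) for inhibition, read by resazurin assay, with a stated time of 72 h (on this read-out higher numbers stand for weaker inhibition of growth and lower numbers for stronger inhibition of growth), compound 1 `Oc1ccccc1Nc1nccc(-c2c[nH]c3ccccc23)n1` gives 570 nM and compound 3 `COc1ccc(Nc2nccc(-c3c[nH]c4ccccc34)n2)c(OC)c1` gives 600 nM, while compound 2 `COCCOc1nc(C)c(-c2ccnc(Nc3ccc(OC)cc3OC)n2)s1` gives 1980 nM. That is the highest number of the three, beyond the scatter from both others, and so the weakest inhibition of growth here. Compound 4 `CCSc1nc(C)c(-c2ccnc(Nc3ccc(OC)cc3OC)n2)s1` remains unmeasured and differs from compound 2 as follows: ethylsulfanyl in place of 2-methoxyethoxy on an aromatic carbon. Ethylsulfanyl thus replaces 2-methoxyethoxy on an aromatic carbon. Going by the values given here, no measured pair isolates a change of this kind, so the expectation is loose. A small step in this assay towards stronger inhibition is expected, hardly beyond the scatter. The estimated move is a 1.5-fold lower number from compound 2 to compound 4 (0.18 log units; within the scatter). For compound 4 the estimated value is 1300 nM, with a range of 500 nM to 3400 nM.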

Compound 4, concentration for 50% growth inhibition: 32400 nM
For compound 4 the middle estimate is 25-fold (1.40 log units) below the measured one; measured number outside the range, above it.
By their numbers in this assay, from the lowest: compounds 1 and 3 (each within the scatter of the next); then compound 2; then compound 4.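

In this assay, the group on this aromatic carbon, next to the ring nitrogen and next to the ring sulfur, clearly affects growth inhibition: ethylsulfanyl in place of 2-methoxyethoxy gives a 16-fold higher number from compound 2 to compound 4 (1.21 log units; beyond the scatter) and a large loss of inhibition. Going by these compounds alone, the earlier compounds held no step at this position, so this is the first sign that the series is sensitive here. Nothing measured accounts for the step.

A single step cannot separate the exchange of oxygen for sulfur from the change in chain. Ethoxy, 2-methoxyethylsulfanyl or a dimethylamino group at this position remain open.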